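Aryl Exchange on the Chain Carbon: Compound 4

The compounds below may be only part of what the source reports. "The series", "measured", "known", "first", "only" and "open" are said of these compounds alone.

Measured compounds:
compound 1 `Cc1ccc(CS/C(=C/c2sccc2C)C(=O)c2ccc(Cl)cc2)cc1` — 10000 nM
compound 2 `Cc1ccc(CS/C(=C/c2ccccc2Br)C(=O)c2ccc(Cl)cc2)cc1` — 10000 nM
compound 3 `Cc1ccc(CS/C(=C/c2ccc(O)cc2)C(=O)c2ccc(Cl)cc2)cc1` — 10000 nM

In a functional assay on DU-145 cells (Homo sapiens) for inhibition, read by trypan blue exclusion, with a stated time of 96 h (on this read-out lower numbers stand for stronger inhibition of growth and higher numbers for weaker inhibition of growth), compound 3 stands level with compound 1 and compound 2: the step of no change at the digits printed from compound 1 to compound 3 (within the scatter) and the step of no change at the digits printed from compound 2 to compound 3 (within the scatter) both stay within the scatter, as does no change at the digits printed from compound 1 to compound 2 (within the scatter). The unmeasured compound 4 `Cc1ccc(CS/C(=C/c2cccc(Cl)c2Cl)C(=O)c2ccc(Cl)cc2)cc1` differs from compound 3 in one place: 2,3-dichlorophenyl in place of 4-hydroxyphenyl on a double-bonded chain carbon bound to a double-bonded chain carbon. For the measured compounds named here, every measured step so far swapped the group on the double-bonded chain carbon bound to a double-bonded chain carbon, and none of them moved the read-out beyond the scatter, so compound 4 is expected to show no step beyond the scatter either, no change at the digits printed from compound 3 to compound 4 (within the scatter). The estimate for compound 4 is therefore 10000 nM, with a range from 5000 nM to 20000 nM.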

Compound 4, concentration for 50% growth inhibition: 25000 nM
Beside the measured number, compound 4's estimate is 2.5-fold (0.40 log units) below it, outside the stated range (above it).
By their numbers in this assay, from the lowest: compounds 1, 2 and 3 (each within the scatter of the next); then compound 4.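

In this assay, the double-bonded chain carbon no longer looks indifferent to its aryl group: 2,3-dichlorophenyl gives a 2.5-fold higher number from compound 3 to compound 4 (0.40 log units; beyond the scatter) and also a 2.5-fold higher number from compound 2 to compound 4 (0.40 log units; beyond the scatter) and a 2.5-fold higher number from compound 1 to compound 4 (0.40 log units; beyond the scatter) on the same read-out, each step modest but beyond the scatter. Compound 4 alone stands apart, with weaker inhibition of growth than the other three compounds. Nothing available accounts for this step.

Going by these compounds, whether an amine or a carboxylic acid on this aryl group would lower the number remains open. So does whether a single chlorine would separate from compounds 1, 2 and 3.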